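A few compounds are considered here, and "the series" means these few. Any claim that something is new, unique, unknown or untested is made for them only; others in the source may bear on it.

Of the compounds shown here, three sharing one core have been tested in an ADME assay on RAW264.7 cells (Mus musculus) for cytotoxicity, read by MTT assay, with a stated time of 48 h; on this read-out higher numbers stand for weaker inhibition and lower numbers for stronger inhibition. Compound 1 `Cc1cc(NC(=O)c2ccc(C#N)cc2)ccc1NS(C)(=O)=O` gives 171000 nM. Compound 2 `CCS(=O)(=O)Nc1ccc(NC(=O)c2ccc(C#N)cc2)cc1C` gives 109000 nM, and compound 3 `Cc1cc(NC(=O)c2ccc(C#N)cc2)ccc1NS(=O)(=O)C(F)(F)F` gives 135000 nM, the second highest of the three numbers. The steps among them, a 1.6-fold lower number from compound 1 to compound 2 (0.20 log units; within the scatter), a 1.3-fold lower number from compound 1 to compound 3 (0.10 log units; within the scatter) and a 1.2-fold higher number from compound 2 to compound 3 (0.09 log units; within the scatter), all lie within the scatter, and each alters only the group on the sulfonyl sulfur. Among the compounds with values here, compound 4 `N#Cc1ccc(C(=O)Nc2ccc(NS(=O)(=O)C(F)(F)F)c(F)c2)cc1` differs from compound 3 by fluoro in place of methyl on an aromatic carbon, a place that none of the measured steps touches, so there is no direct guide. Every measured change left the numbers within the scatter; on that basis compound 4 is expected to show a 1.0-fold lower number from compound 3 to compound 4 (0.02 log units; within the scatter), nothing beyond the scatter. Compound 4 is therefore estimated at 130000 nM, with a range from 60000 nM to 300000 nM.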

Compound 4, half-maximal inhibitory concentration: > 250000 nM
Compound 4: no number, only a limit; the forecaster's own chance of this, stated with the estimate: 20%; middle value at least 1.9-fold (0.28 log units) from the limit.
By their numbers in this assay, from the lowest: compounds 2, 3 and 1 (each within the scatter of the next). At a limit, above all of these: compound 4.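

Within the data shown here, the earlier steps changed only the group on the sulfonyl sulfur, so this is the first look at the aromatic carbon ortho to the ((trifluoromethyl)sulfonyl)amino group. Fluoro in place of methyl there gives an at least 1.8-fold higher number from compound 3 to compound 4 (0.26 log units; that floor lies within the scatter), so the change shows no reach beyond the scatter, yet its true size stays unknown. Compound 4 has a limit in this assay, not a number: the limit of > 250000 nM in this assay, at which 1 of the 4 values shown sits.

Still open, as far as these compounds go, is how a chloro or methoxy group on this carbon would read. Also open, from the compounds shown here alone, is whether fluoro gives a similar step with methyl or ethyl on the sulfonyl sulfur.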